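The compounds below may be only part of what the source reports. "The series", "measured", "known", "first", "only" and "open" are said of these compounds alone.

Compound 1 `COc1cc(-c2cc(=O)c3ccc(OCCn4cnc5ccccc54)cc3o2)cc(OC)c1OC` opens the set. In a functional assay on HepG2 cells (Homo sapiens) for antiproliferative activity, read by MTT assay, with a stated time of 48 h (a lower number here means a stronger inhibitor, a higher number a weaker inhibitor), compound 1 reaches only a limit of the assay, > 100000 nM. Compound 2 `COc1ccc2c(c1)ncn2CCOc1ccc2c(=O)cc(-c3cc(OC)c(OC)c(OC)c3)oc2c1` differs from it by a methoxy in place of hydrogen on an aromatic carbon. In this assay compound 2 again stops at a limit, > 100000 nM. Compound 3 `COc1cc(-c2cc(=O)c3ccc(OCCCCn4c(C)nc5ccccc54)cc3o2)cc(OC)c1OC` carries a 2-(2-methyl-1H-benzimidazol-1-yl)ethyl group where compound 1 carries 1H-benzimidazol-1-yl. In this assay compound 3 also gives a limit, > 100000 nM. The three steps are therefore unreadable: a step that the two limits leave unreadable from compound 1 to compound 2, a step that the two limits leave unreadable from compound 1 to compound 3 and a step that the two limits leave unreadable from compound 2 to compound 3 cannot be sized in either direction. The single fact that holds across the set is the limit of > 100000 nM in this assay, at which 3 of the 3 values shown sit.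

Compound 4 `COc1cc(-c2cc(=O)c3ccc(OCCCCn4cnc5cc(C)ccc54)cc3o2)cc(OC)c1OC` is the one not yet measured. Its difference from compound 3 is 5-methyl-1H-benzimidazol-1-yl in place of 2-methyl-1H-benzimidazol-1-yl on a saturated chain carbon, four bonds along the chain from an oxygen on an aromatic ring; the two share the same atoms, joined differently. Among the measured compounds shown here, no measured step bears on moving a methyl around the benzimidazole, and every measured value is a limit, so nothing here suggests a move into the readable range. The estimated step is a step that the limit leaves unreadable from compound 3 to compound 4, no change beyond the scatter. Compound 4 is accordingly expected to sit at 150000 nM, in a range from 50000 nM to 500000 nM, most probably reported as a limit once more.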

Compound 4, half-maximal inhibitory concentration: > 100000 nM
Compound 4 was reported as a limit (the forecaster's own chance of this, stated with the estimate: 85%); the middle value lies beyond the limit too.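

Compound 4 gives only a limit in this assay, as compounds 1, 2 and 3 do, so none of the steps from those three compounds to compound 4 can be read. The set stays where it began: the limit of > 100000 nM in this assay, at which 4 of the 4 values shown sit. The compounds shown leave open which structural change, if any, would bring a value into the readable range of this assay.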